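A few compounds are considered here, and "the series" means these few. Any claim that something is new, unique, unknown or untested is made for them only; others in the source may bear on it.

Measured in a functional assay on HL-60 cells (Homo sapiens) for inhibition; on this read-out higher numbers stand for weaker inhibition and lower numbers for stronger inhibition:
- compound 1 `Cn1cccc1-c1ncnc2c1ncn2C1O[C@H](CO)[C@@H](O)[C@H]1O`: 15700 nM
- compound 2 `OC[C@H]1OC(n2cnc3c(-c4cc[nH]n4)ncnc32)[C@H](O)[C@@H]1O`: 1170 nM

Of these two numbers, the lower belongs to compound 2, so it is the stronger inhibitor in this assay. The next compound, compound 3 `OC[C@H]1OC(n2cnc3c(-c4ccsc4)ncnc32)[C@H](O)[C@@H]1O`, keeps the shared core and changes one group: thiophen-3-yl in place of 1H-pyrazol-3-yl on an aromatic carbon. For the measured compounds named here, only one measured step bears on this change: a 13-fold lower number from compound 1 to compound 2 (1.13 log units; beyond the scatter). That step is large and beyond the scatter, and it also exchanged one five-membered aromatic ring for another. Going by the values given here, it shows that such an exchange can matter, but it cannot fix the direction here, and no measured compound yet carries thiophen-3-yl. A modest shift towards a lower number is therefore expected, though a higher one remains possible. The expected change is a 2.6-fold lower number from compound 2 to compound 3 (0.41 log units; beyond the scatter). For compound 3 the estimated value is 450 nM, with an expected range from 70 nM to 4000 nM.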

Compound 3, half-maximal inhibitory concentration: 3800 nM
The estimate for compound 3 lay 8.4-fold (0.93 log units) below the measured number, within the range that was stated.
By their numbers in this assay, from the lowest: compound 2; then compound 3; then compound 1.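

In this assay, thiophen-3-yl in place of 1H-pyrazol-3-yl gives a 3.2-fold higher number from compound 2 to compound 3 (0.51 log units; beyond the scatter), so at this position two five-membered aromatic rings of equal heavy-atom count are not interchangeable. Thiophen-3-yl in place of 1-methyl-1H-pyrrol-2-yl gives a 4.1-fold lower number from compound 1 to compound 3 (0.62 log units; beyond the scatter), which places compound 3 between the other two and shows that the choice of ring alone spreads the numbers well beyond the scatter. Of the three rings, only 1H-pyrazol-3-yl carries a hydrogen-bond donor and it gives the lowest number, but nothing available explains this order.

Going by these compounds, whether a phenyl ring or a simple amine at this position would fall below compound 2 remains open. So does whether moving the attachment point, as in thiophen-2-yl, would shift the number.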